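Naphthalen-1-yl in place of naphthalen-2-yl: working notes

The source may hold more compounds than are shown below. What is called first, only, known or untested is meant among the compounds shown, and "the series" means these compounds.

Measured in a functional assay on MDA-MB-231 cells (Homo sapiens) for antiproliferative activity, with a stated time of 5 days; on this read-out lower numbers stand for stronger inhibition and higher numbers for weaker inhibition:
- compound 1 `CC1OC2(C=CC(=O)C=C2)N(c2nc(-c3ccc4ccccc4c3)nn2-c2ccc3ccccc3c2)C1=O`: 60 nM
- compound 2 `CC1OC2(C=CC(=O)C=C2)N(c2nc(-c3ccc4ccccc4c3)nn2-c2ccccc2)C1=O`: 70 nM

Among the measured compounds shown here, compound 2 gives 70 nM, which lies within the scatter of compound 1, its only measured neighbour. The next compound to consider is compound 3 `CC1OC2(C=CC(=O)C=C2)N(c2nc(-c3cccc4ccccc34)nn2-c2ccccc2)C1=O`, which carries naphthalen-1-yl in place of naphthalen-2-yl on an aromatic carbon.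

For the measured compounds named here, the only measured step is a 1.2-fold higher number from compound 1 to compound 2 (0.07 log units; within the scatter), with phenyl in place of naphthalen-2-yl on an aromatic nitrogen. That step sits at a different place, so it bears on the present change only indirectly. Going by the values given here, no measured pair varies the group on this carbon.

In this assay, a step not clearly beyond the scatter is therefore expected, with a slight lean to a higher number that has no measured support. The expected change is a 1.4-fold higher number from compound 2 to compound 3 (0.15 log units; within the scatter). For compound 3 the estimated value is 100 nM, with an expected range of 35 nM to 280 nM. The range is kept wide, as no direct comparison exists.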

Compound 3, half-maximal inhibitory concentration: 100 nM
For compound 3 middle estimate and measured number coincide at the digits printed; measured number inside the range.
By their numbers in this assay, from the lowest: compounds 1, 2 and 3 (each within the scatter of the next).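

In this assay, among the compounds shown here, naphthalen-1-yl in place of naphthalen-2-yl on the aromatic carbon gives a 1.4-fold higher number from compound 2 to compound 3 (0.15 log units; within the scatter) as the first measured step at this position, and both groups have the same atoms and the same two six-membered aromatic rings of carbon only, so the step reports on the point of attachment alone. That step lies within the scatter, so this read-out does not separate the two attachments of the group when phenyl sits on the aromatic nitrogen, and the step of a 1.2-fold higher number from compound 1 to compound 2 (0.07 log units; within the scatter) at that nitrogen also lies within the scatter, leaving neither varied place in the series with a step beyond it so far. No available evidence bears on this result.

The compounds shown leave open whether this carbon keeps the same read-out with a group other than these two carbon-only aromatic groups, such as pyridin-3-yl, a morpholine or a simple methyl. They also leave open whether naphthalen-1-yl on this carbon reads the same when naphthalen-2-yl, rather than phenyl, occupies the aromatic nitrogen.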